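Pyridinyl for imidazolyl: the expected solubility of compound 4

This account rests on a few compounds, and the source may have more. Where it says the series, first, only, none or still open, it means among the compounds named here.

Compound 1 `Cc1nccn1-c1cnc(NCc2c(F)ccc3c2CCO3)c2cn[nH]c(=O)c12`: 7000 nM
Compound 2 `CN(c1ccccc1)c1cnc(NCc2c(F)ccc3c2CCO3)n2cnnc12`: a limit of the assay, < 2000 nM
Compound 3 `CN(c1ccn(C)n1)c1cnc(NCc2c(F)ccc3c2CCO3)n2cnnc12`: 130000 nM

In a physicochemical assay for solubility, read by LC-MS, in phosphate buffer, with a stated time of 24 h, at pH 7.4 (on this read-out lower numbers stand for lower solubility and higher numbers for higher solubility), compound 1 has the lowest of the two numbers, with compound 3 well above it. Compound 2 gives only a limit, (the limit of < 2000 nM in this assay, at which 1 of the 3 values shown sits). Compound 4 `Cc1nc(CO)ccc1-c1cnc(NCc2c(F)ccc3c2CCO3)c2cn[nH]c(=O)c12` differs from compound 1 in one place: 6-(hydroxymethyl)-2-methylpyridin-3-yl in place of 2-methyl-1H-imidazol-1-yl on an aromatic carbon. Going by the values given here, the only measured step, an at least 65-fold higher number from compound 2 to compound 3 (1.81 log units; beyond the scatter), is large but concerns another core and another kind of exchange, so it is only a loose guide that swapping one aromatic ring for another can move this read-out substantially. For compound 4 a moderate rise in solubility is expected, a 2.1-fold higher number from compound 1 to compound 4 (0.33 log units; beyond the scatter), and its value is estimated at 15000 nM within 3500 nM to 60000 nM.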

Compound 4, solubility: 3000 nM
Beside the measured number, compound 4's estimate is 5.0-fold (0.70 log units) above it, outside the stated range (below it).
By their numbers in this assay, from the lowest: compound 4; then compound 1; then compound 3. At a limit, below all of these: compound 2.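

In this assay, the exchange on the aromatic carbon of the shared core gives a 2.3-fold lower number from compound 1 to compound 4 (0.37 log units; beyond the scatter). This is the only step shown at this position, and it shows that replacing the imidazolyl group here need not raise the number. The entering 6-(hydroxymethyl)-2-methylpyridin-3-yl carries 1 hydrogen-bond donor where 2-methyl-1H-imidazol-1-yl carries 0, and that does not come with a higher number here.

From the compounds shown here alone, whether an amine or a carboxylic acid in place of the hydroxymethyl would move the number in this assay stays open. Nothing measured here accounts for the fall.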